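This account rests on a few compounds, and the source may have more. Where it says the series, first, only, none or still open, it means among the compounds named here.

Working notes on the series. Two compounds have numbers in a functional assay on MIA PaCa-2 cells (Homo sapiens) for antiproliferative activity, read by MTT assay, with a stated time of 48 h; a higher number here means a weaker inhibitor, a lower number a stronger inhibitor. Compound 1, `CCCCCc1nc(N)n(CC(=O)Nc2ccccc2)c1-c1ccccc1Br`, gives 40600 nM. Compound 2, `Nc1nc(Cc2ccccc2)c(-c2ccccc2Br)n1CC(=O)Nc1ccccc1`, gives 5700 nM and stands lowest of the two, with compound 1 as its nearest neighbour. Going by the values given here, the single measured step so far is a 7.1-fold lower number from compound 1 to compound 2 (0.85 log units; beyond the scatter), which concerns the substituent on the saturated chain carbon and says nothing directly about substitution on the phenyl ring that enters there.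

Compound 3, `CC(C)(C)c1ccc(Cc2nc(N)n(CC(=O)Nc3ccccc3)c2-c2ccccc2Br)cc1`, awaits measurement in this assay. It differs from compound 2 by tert-butyl in place of hydrogen on an aromatic carbon. Among the compounds with values here, no measured step bears on a change at this place, so there is no precedent to scale the expectation from. Within the data shown here, with the one known step being modest and of a different kind, a change within or only slightly beyond the scatter is expected for compound 3, direction open. The expected step is a 1.4-fold lower number from compound 2 to compound 3 (0.15 log units; within the scatter). Compound 3 is therefore estimated at 4000 nM, with a range from 1200 nM to 14000 nM.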

Compound 3, half-maximal inhibitory concentration: 4900 nM
For compound 3 the middle estimate is 1.2-fold (0.09 log units) below the measured one; low and high end bracket the measured number.
By their numbers in this assay, from the lowest: compounds 3 and 2 (each within the scatter of the next); then compound 1.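

In this assay, going by these compounds alone, the change from benzyl to 4-(tert-butyl)benzyl gives the first reading of substitution on this phenyl ring: a 1.2-fold lower number from compound 2 to compound 3 (0.07 log units; within the scatter), so adding tert-butyl, with its 4 heavy atoms, at this aromatic carbon leaves the number within the scatter. The advantage over the butyl-ended chain of compound 1 also remains with this larger substituent, at an 8.3-fold lower number from compound 1 to compound 3 (0.92 log units; beyond the scatter). No supporting measurement gives a reason for this result.

Going by these compounds, a single substituent at one ring position defines no trend, so it remains open whether an amine, a carboxylic acid or a methoxy group at this carbon would also leave the number unchanged. Also open, on these data alone, is how tert-butyl would read on another carbon of this ring, or with a longer chain linking the ring to the core.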